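This account rests on a few compounds, and the source may have more. Where it says the series, first, only, none or still open, it means among the compounds named here.

Compound 1 `CN(C(=O)c1ccc(F)cc1)c1ccc2[nH]c(-c3n[nH]c4ccccc34)cc2n1`, 9650 nM; compound 2 `CN(C(=O)c1ccccc1)c1ccc2[nH]c(-c3n[nH]c4cc(Cl)ccc34)cc2n1`, 9590 nM; compound 3 `CN(C(=O)c1ccccc1)c1ccc2[nH]c(-c3n[nH]c4cc(C#N)ccc34)cc2n1`, 32800 nM.

All three were measured in a functional assay on A549 cells (Homo sapiens) for antiproliferative activity, read by MTT assay, with a stated time of 72 h; a higher number here means a weaker inhibitor, a lower number a stronger inhibitor. Compound 1 and compound 2 give numbers that lie within the scatter of each other, while compound 3 gives a higher number. Going by the values given here, the only single-point step among them, a 3.4-fold higher number from compound 2 to compound 3 (0.53 log units; beyond the scatter), concerns a change elsewhere in the structure. Compound 4 `CN(c1ccc2[nH]c(-c3n[nH]c4ccccc34)cc2n1)S(=O)(=O)c1ccc(Br)cc1` differs from compound 1 in another place: (4-bromophenyl)sulfonyl in place of (4-fluorophenyl)carbonyl on a nitrogen on an aromatic ring. Among the compounds with values here, no measured step touches this part of the molecule, so nothing bears directly on the change, and the expectation rests only on the narrow spread of the three numbers in this assay. Compound 4 is therefore expected to give 12000 nM (range 4000 nM to 40000 nM), an estimated step of a 1.2-fold higher number from compound 1 to compound 4 (0.09 log units; within the scatter) that is not expected to exceed the scatter.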

Compound 4, half-maximal inhibitory concentration: 19700 nM
Estimate against measurement, compound 4: 1.6-fold (0.22 log units) below; measured number inside the range.
By their numbers in this assay, from the lowest: compounds 2 and 1 (each within the scatter of the next); then compounds 4 and 3 (each within the scatter of the next).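

In this assay, going by these compounds alone, this exchange on the nitrogen on an aromatic ring moves the number by a modest step beyond the scatter (a 2.0-fold higher number from compound 1 to compound 4 (0.31 log units; beyond the scatter)), the only measured step at this position. The change replaces carbonyl with sulfonyl and fluorine with bromine together, so the step cannot be assigned to either part alone. Nothing shown accounts for the step.

A (4-bromophenyl)carbonyl or (4-fluorophenyl)sulfonyl group would separate the two parts of the change. On these data alone, whether an amine or a carboxylic acid on this phenyl ring would lower the number remains open.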